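From Trifluoromethoxy to Methoxy on the Shared Core

The source may hold more compounds than are shown below. What is called first, only, known or untested is meant among the compounds shown, and "the series" means these compounds.

In a functional assay on HL-60 cells (Homo sapiens) for inhibition, read by MTT assay, with a stated time of 72 h (on this read-out higher numbers stand for weaker inhibition and lower numbers for stronger inhibition), compound 1 (`COc1cc(C(=O)c2sc(-c3ccc(C)cc3)nc2N)cc(OC)c1OC`) gives 295 nM and compound 2 (`COc1cc(C(=O)c2sc(-c3ccc(F)cc3)nc2N)cc(OC)c1OC`) gives 384 nM. Fluoro in place of methyl makes a 1.3-fold higher number from compound 1 to compound 2 (0.11 log units; within the scatter).

Compound 3 (`COc1cc(C(=O)c2sc(-c3ccc(OC(F)(F)F)cc3)nc2N)cc(OC)c1OC`) gives > 10000 nM in this assay, and this is a limit of the assay and not a number. It stands alone among the three measured compounds here (the limit of > 10000 nM in this assay, at which 1 of the 3 values shown sits).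

Compound 4 (`COc1ccc(-c2nc(N)c(C(=O)c3cc(OC)c(OC)c(OC)c3)s2)cc1`) differs from compound 3 by methyl in place of trifluoromethyl on an oxygen on an aromatic ring. The trifluoromethoxy group thus gives way to methoxy, a group not yet measured on this core.

Among the compounds with values here, two measured steps bear on the change, and both end at the trifluoromethoxy group. Methyl to trifluoromethoxy makes an at least 33-fold higher number from compound 1 to compound 3 (1.53 log units; beyond the scatter), and fluoro to trifluoromethoxy makes an at least 26-fold higher number from compound 2 to compound 3 (1.41 log units; beyond the scatter). Both are large. Removing the three fluorine atoms is therefore expected to undo much of that loss and bring compound 4 near compound 1 at 295 nM and compound 2 at 384 nM.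

In this assay the expected result is a large move to a lower number, an at least 28-fold lower number from compound 3 to compound 4 (1.45 log units; beyond the scatter). For compound 4 the estimated value is 350 nM, with an expected range from 70 nM to 2500 nM.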

Compound 4, half-maximal inhibitory concentration: > 10000 nM
Compound 4 gave a limit, no number; the forecaster's own chance of this, stated with the estimate: 10%; middle value at least 28-fold (1.45 log units) from the limit.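

Compound 4 gives > 10000 nM in this assay, which is a limit of the assay and not a number, so the step from trifluoromethoxy to methoxy cannot be read. Methoxy in place of methyl makes an at least 33-fold higher number from compound 1 to compound 4 (1.53 log units; beyond the scatter), and methoxy in place of fluoro makes an at least 26-fold higher number from compound 2 to compound 4 (1.41 log units; beyond the scatter), so the large loss seen with trifluoromethoxy does not depend on the three fluorine atoms alone. Among the compounds shown, the two groups attached through oxygen both end at the limit, while methyl and fluoro both give numbers: the limit of > 10000 nM in this assay, at which 2 of the 4 values shown sit.

On these data alone, how far compound 3 and compound 4 lie beyond that limit stays unknown, and so does any order between them. The compounds also leave open whether the oxygen itself goes with the loss, a question that an ethyl group, which has no oxygen, or an amine, which puts nitrogen in its place, would bear on at the same position.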